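Working notes: methyl on the piperidine ring, compound 4

The source may report more compounds than this note shows. Statements on the series, on what has been measured and on what is new or still open speak of the compounds shown alone.

Values come from a functional assay on A549 cells (Homo sapiens) for inhibition, read by MTT assay, with a stated time of 72 h; a higher number here means a weaker inhibitor, a lower number a stronger inhibitor. Measured so far:

compound 1, `COc1cc2c(Oc3ccc(NC(=O)c4nn(-c5cccc(F)c5)c(=O)cc4C)cc3F)ccnc2cc1OCCCN1CCC(C)CC1`: compound 1 gives 250 nM
compound 2, `COc1ccc(-n2nc(C(=O)Nc3ccc(Oc4ccnc5cc(OCCCN6CCC(C)CC6)c(OC)cc45)c(F)c3)c(C)cc2=O)cc1`: compound 2 gives 1100 nM
compound 3, `COc1cc2c(Oc3ccc(NC(=O)c4nn(-c5ccc(Cl)cc5Cl)c(=O)cc4C)cc3F)ccnc2cc1OCCCN1CCCCC1`: compound 3 gives 220 nM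

Compound 3 carries the lowest number of the three, but its gap to compound 1 lies within the scatter, so no order between those two is claimed; the number of compound 2 sits clearly higher than that of compound 3.

Compound 4, `COc1cc2c(Oc3ccc(NC(=O)c4nn(-c5ccc(Cl)cc5Cl)c(=O)cc4C)cc3F)ccnc2cc1OCCCN1CCC(C)CC1`, differs from compound 3 by methyl in place of hydrogen on a saturated ring carbon. Among the measured compounds shown here, no measured step changes this position: the single measured step, a 4.4-fold higher number from compound 1 to compound 2 (0.64 log units; beyond the scatter), changes the aromatic group on the ring nitrogen and does not bear on the piperidine ring. Compound 1 and compound 2 already carry the 4-methylpiperidin-1-yl group while compound 3 carries piperidin-1-yl, but each of those pairs also differs at the aromatic group, so no clean comparison exists.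

With nothing in the series pointing either way, compound 4 is expected to sit close to compound 3, a step of no change at the digits printed from compound 3 to compound 4 (within the scatter) in this assay, i.e. none beyond the scatter. The estimate for compound 4 is 220 nM, with a range from 90 nM to 550 nM.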

Compound 4, half-maximal inhibitory concentration: 200 nM
The estimate for compound 4 lay 1.1-fold (0.04 log units) above the measured number; the measured number falls inside the stated range.
By their numbers in this assay, from the lowest: compounds 4, 3 and 1 (each within the scatter of the next); then compound 2.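

In this assay, among the compounds shown here, methyl in place of hydrogen on the saturated ring carbon three ring bonds from the ring nitrogen gives a 1.1-fold lower number from compound 3 to compound 4 (0.04 log units; within the scatter), the first clean reading at this position: with 2,4-dichlorophenyl on the aromatic nitrogen, piperidin-1-yl and 4-methylpiperidin-1-yl cannot be told apart. With 4-methylpiperidin-1-yl held fixed, 2,4-dichlorophenyl in place of 4-methoxyphenyl gives a 5.5-fold lower number from compound 2 to compound 4 (0.74 log units; beyond the scatter), whereas 2,4-dichlorophenyl in place of 3-fluorophenyl gives a 1.3-fold lower number from compound 1 to compound 4 (0.10 log units; within the scatter), so among these three compounds only the 4-methoxyphenyl member stands apart. No data bearing on the cause of these steps are available.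

Going by these compounds, it remains open whether the methyl step would read the same with 3-fluorophenyl or 4-methoxyphenyl on the aromatic nitrogen. Also open, on these data alone, is whether a hydroxyl, a carboxylic acid or a dimethylamino group on the same ring carbon would shift the number in this assay.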